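Adding a Fluorine to the Anilino Ring of Compound 2

The source may hold more compounds than are shown below. What is called first, only, known or untested is meant among the compounds shown, and "the series" means these compounds.

Of the compounds shown here, three built around a shared bicyclic amine have been measured in an assay on cell membranes for displacement of a labelled ligand from Neuronal acetylcholine receptor; alpha4/beta2 (Rattus norvegicus); on this read-out lower numbers stand for stronger inhibition and higher numbers for weaker inhibition. Compound 1 `COc1ccc(Nc2cncc(N3CC4CC(C3)N4)c2)cc1` gives 0.0598 nM. Compound 2 `c1ccc(Nc2ccc(N3CC4CC(C3)N4)cn2)cc1` gives 2.66 nM, and compound 3 `Fc1ccc(Nc2ccc(N3CC4CC(C3)N4)nn2)cc1` gives 868 nM. Among these three numbers compound 2 stands second highest: compound 1 lies far below it, beyond the usual scatter, and compound 3 lies far above it, also beyond the scatter. Among the compounds with values here, none of the three pairs differs in a single place, so no individual step between measured compounds can be read off.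

Compound 4 `Fc1ccc(Nc2ccc(N3CC4CC(C3)N4)cn2)cc1` has not yet been measured. It differs from compound 2 in one place, (fluoro in place of hydrogen on an aromatic carbon). Compound 3 also carries a fluoro group on its aryl ring, but its core differs from that of compound 2 as well, so the two values of compound 2 and compound 3 show only a large gap between different scaffolds and say nothing on their own about the fluoro group.

Within the data shown here, with no matched step to lean on, the expectation for the step from compound 2 to compound 4 is a change of no more than the scatter in either direction, that is a 1.1-fold higher number from compound 2 to compound 4 (0.05 log units; within the scatter). Compound 4 is therefore estimated to give 3 nM in this assay, with a range from 0.8 nM to 12 nM.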

Compound 4, inhibition constant: 2.38 nM
For compound 4 the middle estimate is 1.3-fold (0.10 log units) above the measured one; measured number inside the range.
By their numbers in this assay, from the lowest: compound 1; then compounds 4 and 2 (each within the scatter of the next); then compound 3.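

In this assay, within the data shown here, replacing phenyl with 4-fluorophenyl on the core of compound 2 gives a 1.1-fold lower number from compound 2 to compound 4 (0.05 log units; within the scatter), the first step in this set that can be read at a single place, and it shows that fluoro can stand in place of hydrogen here, para to a large group, with no difference beyond the scatter. Compound 4 gives 2.38 nM and compound 3, which carries the same 4-fluorophenyl group on another core, gives 868 nM, so carrying that group does not by itself go with a number as high as that of compound 3. Nothing measured here speaks to why the fluoro step is so small.

Going by these compounds, whether the same place accepts other groups just as readily stays open, for example a trifluoromethyl, an amine or a carboxylic acid in place of the fluoro group. Compound 1 carries a methoxy group but differs from compound 2 in more than one place, so how much of its lower number belongs to that group on the core of compound 2 cannot be read from these compounds.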